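Methoxy to hydroxy in a cytotoxicity measurement

A few compounds are considered here, and "the series" means these few. Any claim that something is new, unique, unknown or untested is made for them only; others in the source may bear on it.

Compound 1 `O=C(/C=C/c1coc2cc(O)ccc2c1=O)NCc1ccccc1` gives 436000 nM
Compound 2 `COc1ccc2c(=O)c(/C=C/C(=O)NCc3ccc(C)cc3)coc2c1` gives 257000 nM

In an ADME assay on HepG2 2.2.15 cells (Homo sapiens) for cytotoxicity, read by MTT assay, with stated times of 48 h and 9 days (a higher number here means that more compound is tolerated, a lower number that less compound is tolerated), compound 2 gives 257000 nM and sits within the scatter of compound 1, so the two values cannot be told apart. Compound 3 `Cc1ccc(CNC(=O)/C=C/c2coc3cc(O)ccc3c2=O)cc1` has not yet been measured. It differs from compound 2 by hydrogen in place of methyl on an oxygen on an aromatic ring with hydrogen in place of methyl on an oxygen on an aromatic ring, which reads as methoxy to hydroxy. Going by the values given here, no measured pair isolates this change. Among the compounds with values here, the only hint comes from compound 1, which also carries the hydroxy and gives 436000 nM in the same range. The estimated step of a 1.3-fold higher number from compound 2 to compound 3 (0.12 log units; within the scatter) is therefore a slight rise, not expected to exceed the scatter. For compound 3 the expected value is 340000 nM with an estimated range from 150000 nM to 750000 nM in this assay as the likely outcome.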

Compound 3, half-maximal cytotoxic concentration: 501000 nM
Estimate against measurement, compound 3: 1.5-fold (0.17 log units) below; the measured number falls inside the stated range.
By their numbers in this assay, from the lowest: compounds 2, 1 and 3 (each within the scatter of the next).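

In this assay, the change from methoxy to hydroxy now stands alone as a 1.9-fold higher number from compound 2 to compound 3 (0.29 log units; within the scatter), so on this oxygen on an aromatic ring the two groups cannot be told apart. The other single change, methyl in place of hydrogen on an aromatic carbon, gives a 1.1-fold higher number from compound 1 to compound 3 (0.06 log units; within the scatter), and it too lies within the scatter, so neither change separates the compounds in this read-out. No evidence is available that would explain these results.

Going by these compounds, it remains open whether a different group on this oxygen, such as ethoxy, or an amine in place of the hydroxy, would move the number beyond the scatter. The same question stands for a chlorine or a longer chain on the aromatic carbon that carries the methyl.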